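A Cyclohexyl Ring in Place of a Pentyl Chain

The source may report more compounds than this note shows. Statements on the series, on what has been measured and on what is new or still open speak of the compounds shown alone.

Compounds measured so far:
- compound 1, `CCCCCC[C@@H](C)NC(=S)Nc1ccc(F)c(Cl)c1`: 49100 nM
- compound 2, `CCCCCC[C@@H](C)Nc1nc2cc(Cl)c(F)cc2s1`: 48000 nM
- compound 3, `COc1ccc([C@H](C)Nc2nc3cc(Cl)c(F)cc3s2)cc1`: "not determined" (no result reported)

In a functional assay on HeLa cells (Homo sapiens) for cytotoxicity, read by MTT assay, with a stated time of 24 h (a lower number here means a stronger inhibitor, a higher number a weaker inhibitor), compound 1 gives 49100 nM. Compound 2, which carries the same hexyl-bearing side chain on a different core, gives 48000 nM in this assay, and the two numbers lie within the usual scatter of each other, so nothing separates them. Going by the values given here, compound 3 gives "not determined" (no result reported) in this assay, so only two numbers are known, and both describe weak inhibitors.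

Compound 4, `C[C@H](CC1CCCCC1)NC(=S)Nc1ccc(F)c(Cl)c1`, is the next compound, and it differs from compound 1 in one place: cyclohexyl in place of pentyl on a saturated chain carbon, two bonds along the chain from an amide-type nitrogen. The change keeps the same core of compound 1 and the same amide-type nitrogen, and only reshapes the saturated side chain, with cyclohexyl entering where pentyl leaves. Among the compounds with values here, no pair of measured compounds differs in this way, so there is no measured step to lean on. Within the data shown here, since the two known numbers are alike and the change leaves the core untouched, the step from compound 1 to compound 4 is expected to be small, within the scatter, in either direction a 1.1-fold lower number from compound 1 to compound 4 (0.04 log units; within the scatter). Compound 4 is therefore estimated at 45000 nM in this assay, with a range from 18000 nM to 110000 nM.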

Compound 4, half-maximal inhibitory concentration: 45800 nM
Beside the measured number, compound 4's estimate is 1.0-fold (0.01 log units) below it, and the stated range covers the measured number.
By their numbers in this assay, from the lowest: compounds 4, 2 and 1 (each within the scatter of the next).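

Placing cyclohexyl in place of pentyl on a saturated chain carbon, two bonds along the chain from an amide-type nitrogen, gives a 1.1-fold lower number from compound 1 to compound 4 (0.03 log units; within the scatter) in this assay and so leaves the two compounds indistinguishable. Going by these compounds alone, this is the first measured step at this position, and it shows that an open pentyl chain and a six-membered ring of carbon only can occupy this place on the shared core with no readable difference, while compound 4 stays a weak inhibitor at 45800 nM in this test of cell killing. Nothing in the data shown gives a reason for this result.

From the compounds shown here alone, both groups compared here consist of carbon and hydrogen only, so it remains open whether an amine, a carboxylic acid or a much longer chain at this place would move the number beyond the scatter. Going by these compounds, it is also open whether cyclohexyl would behave the same way on the core of compound 2, since a single step on one core says nothing about another.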